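Notes on fluorophenyl sulfonylamino chain analogues

The source may report more compounds than this note shows. Statements on the series, on what has been measured and on what is new or still open speak of the compounds shown alone.

Measured in a functional assay on cells (Panel CNS (Carcinoma cell lines), Homo sapiens) for inhibition, read by sulforhodamine B assay, with a stated time of 48 h (on this read-out higher numbers stand for weaker inhibition and lower numbers for stronger inhibition), so far
- compound 1 `CN1CCCN(CCNc2nccc(-c3c(-c4cccc(O)c4)nc4sccn34)n2)S1(=O)=O` gives 16400 nM as its value
- compound 2 `O=S(=O)(NCCCNc1nccc(-c2c(-c3cccc(O)c3)nc3sccn23)n1)c1cccc(F)c1` gives 3190 nM as its value

Not yet measured
- compound 3 `O=S(=O)(NCCNc1nccc(-c2c(-c3cccc(O)c3)nc3sccn23)n1)c1ccc(F)cc1`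

Compound 2 holds the lower of the two numbers at 3190 nM as measured. Compound 3 differs from it by ((4-fluorophenyl)sulfonyl)amino in place of (((3-fluorophenyl)sulfonyl)amino)methyl on a saturated chain carbon, two bonds along the chain from a nitrogen on an aromatic ring in all: ((4-fluorophenyl)sulfonyl)amino in place of (((3-fluorophenyl)sulfonyl)amino)methyl. Among the compounds with values here, the one measured step of a 5.1-fold lower number from compound 1 to compound 2 (0.71 log units; beyond the scatter) involved a different exchange and bears only indirectly here. Within the data shown here, no measured pair tests this exchange alone. No step beyond the scatter is therefore expected in this assay for this change. The expected 1.1-fold higher number from compound 2 to compound 3 (0.04 log units; within the scatter) is small and uncertain. For compound 3 the estimate is 3500 nM within 1200 nM to 10000 nM as the expected range.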

Compound 3, half-maximal inhibitory concentration: 7580 nM
Compound 3: the middle estimate sits 2.2-fold (0.34 log units) below what was measured; the measured number falls inside the stated range.
By their numbers in this assay, from the lowest: compound 2; then compound 3; then compound 1.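

In this assay, a 2.4-fold higher number from compound 2 to compound 3 (0.38 log units; beyond the scatter) shows that this position responds to replacing (((3-fluorophenyl)sulfonyl)amino)methyl with ((4-fluorophenyl)sulfonyl)amino. The shorter fluorophenyl group still holds an advantage over the group with the non-aromatic six-membered ring, with a 2.2-fold lower number from compound 1 to compound 3 (0.34 log units; beyond the scatter) as the step. Nothing measured here accounts for either step.

The exchange alters chain length and fluorine placement together, so their separate contributions remain unresolved. Also open, going by these compounds, is how an amine or a carboxylic acid in place of the fluorophenyl ring, or a longer chain, would read in this assay.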